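Swapping the carboxyphenylsulfonyl arm for a piperidinyl carbonyl

The compounds below may be only part of what the source reports. "The series", "measured", "known", "first", "only" and "open" are said of these compounds alone.

Measured compounds:
compound 1, `O=C(c1ccc(Cl)cc1)N1CCC(NS(=O)(=O)c2cc(S(=O)(=O)c3ccccc3)ccc2C(F)(F)F)CC1`: 300 nM
compound 2, `O=C(c1ccccn1)N1CCC(NS(=O)(=O)c2cc(S(=O)(=O)c3ccccc3)ccc2C(F)(F)F)CC1`: 60 nM
compound 3, `O=C(O)c1ccc(S(=O)(=O)N2CCC(NS(=O)(=O)c3cc(S(=O)(=O)c4ccccc4)ccc3C(F)(F)F)CC2)cc1`: 20 nM

All three share one core and differ only in the group on the amine nitrogen in the ring. In an assay on isolated protein for displacement of a labelled ligand from secreted frizzled-related protein 1 (Homo sapiens), read by fluorescence polarization, with a stated time of 30 min (a higher number here means a weaker inhibitor, a lower number a stronger inhibitor), compound 3 gives the lowest number of the three; compound 2 sits above it by a 3.0-fold lower number from compound 2 to compound 3 (0.48 log units; beyond the scatter), and compound 1 further above it by a 15-fold lower number from compound 1 to compound 3 (1.18 log units; beyond the scatter), so compound 3 is the strongest inhibitor among these.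

Compound 4, `O=C(C1CCNCC1)N1CCC(NS(=O)(=O)c2cc(S(=O)(=O)c3ccccc3)ccc2C(F)(F)F)CC1`, has not yet been measured. It differs from compound 3 in one place: (piperidin-4-yl)carbonyl in place of (4-carboxyphenyl)sulfonyl on an amine nitrogen in a ring. Within the data shown here, two measured steps bear on this. Both a 15-fold lower number from compound 1 to compound 3 (1.18 log units; beyond the scatter) and a 3.0-fold lower number from compound 2 to compound 3 (0.48 log units; beyond the scatter) show that the (4-carboxyphenyl)sulfonyl gave lower numbers than a carbonyl-attached aromatic group. Compound 4 returns to a carbonyl and carries a non-aromatic ring, so a step back upward in this assay is expected, of a size between those two measured steps. Compound 4 is therefore estimated at 150 nM, with a range of 40 nM to 600 nM, an expected step of a 7.5-fold higher number from compound 3 to compound 4 (0.88 log units; beyond the scatter).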

Compound 4, half-maximal inhibitory concentration: 120 nM
Compound 4: middle estimate off by 1.3-fold (0.10 log units), on the high side; the measured number falls inside the stated range.
By their numbers in this assay, from the lowest: compound 3; then compounds 2 and 4 (each within the scatter of the next); then compound 1.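

In this assay the step of a 2.5-fold lower number from compound 1 to compound 4 (0.40 log units; beyond the scatter) and the step of a 2.0-fold higher number from compound 2 to compound 4 (0.30 log units; within the scatter) show that a non-aromatic ring on the carbonyl can stand in for the aromatic groups: it improves on 4-chlorophenyl, and it cannot be told apart from pyridin-2-yl. The step of a 6.0-fold higher number from compound 3 to compound 4 (0.78 log units; beyond the scatter) extends the lead of the (4-carboxyphenyl)sulfonyl group to a non-aromatic carbonyl partner, so compound 3 remains the strongest inhibitor of the four. No data are at hand that would explain these differences.

The compounds shown change the linking group and the ring together, so they cannot say whether the sulfonyl or the carboxylic acid accounts for the lower number of compound 3. A (4-carboxyphenyl)carbonyl group and a plain phenylsulfonyl group on the same nitrogen would separate the two.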